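A Second Methyl on the Ring of Compound 3

A few compounds are considered here, and "the series" means these few. Any claim that something is new, unique, unknown or untested is made for them only; others in the source may bear on it.

Three compounds have been measured in a functional assay on CHO cells for positive allosteric modulation of metabotropic glutamate receptor 2 (Homo sapiens), read by scintillation counting and GTPgammaS binding, with a stated time of 30 min; a higher number here means a larger maximal response, a lower number a smaller maximal response:

compound 1 `CC(C)CCn1ccc(-c2ccc(Oc3ccncc3)cc2)c(C#N)c1=O` gives 245%
compound 2 `Cc1cc(Oc2ccc(-c3ccn(CCC(C)C)c(=O)c3C#N)cc2)ccn1` gives 266%
compound 3 `CCCCn1ccc(-c2ccc(Oc3cccnc3C)cc2)c(C#N)c1=O` gives 228%

Compound 1 and compound 2 share one core and differ in a single place, (methyl in place of hydrogen on an aromatic carbon). This change moved the maximal response by a number 21 percentage points higher from compound 1 to compound 2 (beyond the scatter), a modest rise that lies beyond the scatter.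

Compound 3 is built from the same atoms as compound 1, joined differently; the difference between the two cores is not broken down here. In this assay compound 3 gives the lowest of the three numbers: it sits below compound 1 and further below compound 2, both gaps beyond the scatter.

Compound 4 `CCCCn1ccc(-c2ccc(Oc3ccc(C)nc3C)cc2)c(C#N)c1=O` has not yet been measured. It differs from compound 3 by methyl in place of hydrogen on an aromatic carbon. The surroundings are not identical to those in compound 2: there the methyl entered next to the ring nitrogen and meta to a large group, here it enters next to the ring nitrogen, meta to a methyl group and para to a large group. It is therefore the same kind of change, not the same change.

On that basis a step of a number 14 percentage points higher from compound 3 to compound 4 (beyond the scatter) is expected for compound 4, resting on the rise seen in a number 21 percentage points higher from compound 1 to compound 2 (beyond the scatter). Compound 4 is estimated to give 242% in this assay, with a likely range from 212% to 272%.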

Compound 4, largest response reached (Emax), in percent of the reference or control that the assay uses: 239%
Compound 4: middle estimate off by 3 percentage points, on the high side; the measured number falls inside the stated range.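

In this assay, putting a methyl on the pyridine ring of compound 3, turning 2-methylpyridin-3-yl into 2,6-dimethylpyridin-3-yl, gave a number 11 percentage points higher from compound 3 to compound 4 (beyond the scatter) as a modest rise in the maximal response. The same change has now raised the number on both cores, and the two steps cannot be told apart in size: the same change on two cores in this assay, a number 21 percentage points higher (beyond the scatter) from compound 1 to compound 2 and a number 11 percentage points higher (beyond the scatter) from compound 3 to compound 4, 10 percentage points apart, within the scatter of two such steps. This shows only that the rise carried over between these two cores in this one assay; with just two pairs of compounds, it does not show that the rise would appear on any other core, and it gives no reason for the rise, nor does it show that the step has one fixed size, as the methyl enters different surroundings in each pair.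

The compounds shown leave open whether something other than methyl on the same ring carbon, such as an ethyl group, a methoxy group or an amine, would also raise the maximal response. They also leave open whether the same methyl would still give a rise on a core carrying a longer chain on the ring nitrogen of the shared core.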